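Methoxycarbonyl on the Pyridine of a Ketone-Oxazole Inhibitor

The source may hold more compounds than are shown below. What is called first, only, known or untested is meant among the compounds shown, and "the series" means these compounds.

Compound 1, `O=C(CCc1ccc(-c2ccccc2)cc1)c1ncc(-c2cccnc2)o1`, is the stronger of the two measured compounds in an assay for inhibition of Fatty-acid amide hydrolase 1 (Rattus norvegicus) (a higher number here means a weaker inhibitor, a lower number a stronger inhibitor), where compound 1 gives 1.1 nM. Within the data shown here, the only other measured compound, compound 2, `CN1CCN(Cc2ccc(-c3ccc(CCC(=O)c4ncc(-c5cccc(C(=O)O)n5)o4)cc3)cc2)CC1`, carries a carboxylic acid and a methylpiperazine group and gives a far higher number, 1200 nM, a gap well beyond the scatter. Compound 3, `COC(=O)c1ccc(-c2cnc(C(=O)CCc3ccc(-c4ccccc4)cc3)o2)cn1`, is compound 1 with one change: methoxycarbonyl in place of hydrogen on an aromatic carbon. Among the measured compounds shown here, no step between measured compounds shows what this change alone does, since compound 2 differs in two places at once. A small loss of potency is expected, because compound 2 with a related group on the same ring gives 1200 nM, but the two other differences there make that weak evidence. The step from compound 1 to compound 3 is expected to be a 2.7-fold higher number from compound 1 to compound 3 (0.44 log units; beyond the scatter), within or barely beyond the scatter. Compound 3 is estimated at 3 nM, between 0.7 nM and 15 nM.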

Compound 3, inhibition constant: 0.6 nM
Estimate against measurement, compound 3: 5.0-fold (0.70 log units) above; the whole stated range lies above it.
By their numbers in this assay, from the lowest: compounds 3 and 1 (each within the scatter of the next); then compound 2.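

Placing methoxycarbonyl on the aromatic carbon next to the ring nitrogen and para to a large group gives, in this assay, a 1.8-fold lower number from compound 1 to compound 3 (0.26 log units; within the scatter). Among these compounds, this is the first step that isolates this change, and it shows that this position can carry a group of 4 heavy atoms, with no ring, without a loss of potency beyond the scatter, so compound 1 and compound 3 cannot be told apart in this assay. Nothing measured on these compounds accounts for this result.

As far as these compounds go, whether the same position also accepts an amide, an aminomethyl group or a longer ester such as ethoxycarbonyl remains open. It is also unknown whether methoxycarbonyl would give a similar result on another carbon of the same ring.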